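Methyl for Fluoro: A Small Change on Compound 2

A few compounds are considered here, and "the series" means these few. Any claim that something is new, unique, unknown or untested is made for them only; others in the source may bear on it.

Of the compounds shown here, three sharing one core have been tested in a functional assay on CCRF-CEM cells (Homo sapiens) for cytotoxicity, read by MTT assay, with a stated time of 72 h; on this read-out lower numbers stand for stronger inhibition of growth and higher numbers for weaker inhibition of growth. Compound 1 `N#C[Se]c1ccc(NC(=O)OCc2ccc([N+](=O)[O-])cc2)cc1` gives 38300 nM, compound 2 `N#C[Se]c1ccc(NC(=O)Oc2ccc(F)cc2)cc1` gives 41900 nM, and compound 3 `CCOC(=O)Nc1ccc([Se]C#N)cc1` gives 39100 nM. Compound 2 holds the highest of the three numbers, yet its gaps to compound 3 and to compound 1 both fall within the usual scatter, so the three cannot be told apart. Compound 4 `Cc1ccc(OC(=O)Nc2ccc([Se]C#N)cc2)cc1` has not yet been measured. It differs from compound 2 in one place: methyl in place of fluoro on an aromatic carbon. Within the data shown here, no measured pair shows a step of this kind, so nothing beyond the three values at hand can guide the expectation. The expected step of a 1.0-fold lower number from compound 2 to compound 4 (0.02 log units; within the scatter) is none beyond the scatter. Compound 4 is therefore estimated at 40000 nM, within 20000 nM to 80000 nM.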

Compound 4, concentration for total growth inhibition: 44700 nM
Beside the measured number, compound 4's estimate is 1.1-fold (0.05 log units) below it, within the range that was stated.
By their numbers in this assay, from the lowest: compounds 1, 3, 2 and 4 (each within the scatter of the next).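

Among these compounds, this is the first measured step at this position, on an aromatic carbon para to a large group: in this assay, methyl in place of fluoro gives a 1.1-fold higher number from compound 2 to compound 4 (0.03 log units; within the scatter). In this one pair, then, the two groups cannot be told apart at this place. No measurement at hand bears on this result.

Still open, as far as these compounds go, is whether a different group at the same place, such as an amine, a carboxylic acid or a longer chain, would shift the number beyond the scatter.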